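Dichloro substitution on a sulfonamide series at the assay limit

The source may hold more compounds than are shown below. What is called first, only, known or untested is meant among the compounds shown, and "the series" means these compounds.

Compound 1 `O=S(=O)(NC1=NCCN1C(=S)SN1CCn2c1nsc2=S)c1ccccc1` carries a plain phenyl on its sulfonyl sulfur. In a functional assay on KYSE-510 cells (Homo sapiens) for antiproliferative activity, read by crystal violet staining, with a stated time of 96 h (a lower number here means a stronger inhibitor of growth, a higher number a weaker inhibitor of growth), compound 1 gives >= 20000 nM, which is a limit of the assay and not a number. Compound 2 `COc1ccc(S(=O)(=O)NC2=NCCN2C(=S)SN2CCn3c2nsc3=S)cc1OC` bears a 3,4-dimethoxyphenyl at the same position. In this assay compound 2 gives >= 20000 nM, again a limit. Compound 3 `O=S(=O)(NC1=NCCN1C(=S)SN1CCn2c1nsc2=S)c1ccc(Cl)cc1` carries a 4-chlorophenyl. In this assay compound 3 gives >= 20000 nM, also a limit. Among the measured compounds shown here, because all three values sit at the limit of >= 20000 nM in this assay, at which 3 of the 3 values shown sit, none of the measured steps can be read: a step that the two limits leave unreadable from compound 1 to compound 2, a step that the two limits leave unreadable from compound 1 to compound 3 and a step that the two limits leave unreadable from compound 2 to compound 3 are all of unreadable size, so compound 1 stands only at the limit alongside the others.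

Compound 4 `O=S(=O)(NC1=NCCN1C(=S)SN1CCn2c1nsc2=S)c1ccc(Cl)cc1Cl` is the unmeasured member. 2,4-dichlorophenyl in place of phenyl on a sulfonyl sulfur The step from compound 1 to compound 3 is the one that bears most on this change, and it gave no readable size. The author therefore expects no step beyond the scatter in this assay, with the result most likely again at the limit. The step from compound 1 to compound 4 is estimated at a number no higher from compound 1 to compound 4 (the limit leaves the size open). Compound 4 is estimated at 20000 nM, within a range from 8000 nM to 50000 nM.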

Compound 4, concentration for 50% growth inhibition: >= 20000 nM
Compound 4 gave a limit, no number (the forecaster's own chance of this, stated with the estimate: 80%); the middle value lies on the limit itself.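

In this assay compound 4 gives >= 20000 nM, which is a limit and not a number. Its steps from compound 1, compound 2 and compound 3 therefore cannot be read: the limit of >= 20000 nM in this assay, at which 4 of the 4 values shown sit.

The compounds shown leave open how strongly any of the four inhibits growth, and whether the group on the sulfonyl sulfur affects that inhibition at all.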